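Adding a Second Methoxy to a Lactone Growth Inhibitor

The compounds below may be only part of what the source reports. "The series", "measured", "known", "first", "only" and "open" are said of these compounds alone.

Compound 1 `O=C1C=COC(/C=C/c2ccccc2)C1` and compound 2 `COc1ccc(/C=C/C2CC(=O)C=CO2)cc1` share a core, and compound 3 `COc1ccc(/C=C/C2CC=CC(=O)O2)cc1` carries a different core; the difference between the two cores is not broken down here. In a functional assay on MCF7 cells (Homo sapiens) for inhibition, read by sulforhodamine B assay, with a stated time of 48 h (a higher number here means a weaker inhibitor of growth, a lower number a stronger inhibitor of growth), compound 1 gives 153 uM, compound 2 gives 156 uM, and compound 3 gives 25.5 uM. The change from compound 1 to compound 2 is methoxy in place of hydrogen on an aromatic carbon, and it made a 1.0-fold higher number from compound 1 to compound 2 (0.01 log units; within the scatter). Compound 4 `COc1ccc(/C=C/C2CC=CC(=O)O2)c(OC)c1` is the not yet measured partner of compound 3, reached by methoxy in place of hydrogen on an aromatic carbon. This is the same kind of change, though not the same: in compound 2 the new group sits para to a group of 9 heavy atoms, while in compound 4 it sits ortho to a group of 9 heavy atoms and meta to a methoxy group. Because the earlier step of a 1.0-fold higher number from compound 1 to compound 2 (0.01 log units; within the scatter) stayed within the scatter, the expectation for compound 4 in this assay is a step of about a 1.0-fold lower number from compound 3 to compound 4 (0.01 log units; within the scatter). Compound 4 is therefore estimated at 25 uM, most likely between 10 uM and 65 uM.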

Compound 4, concentration for growth inhibition (reported as GI): 5.4 uM
Estimate against measurement, compound 4: 4.6-fold (0.67 log units) above; measured number outside the range, below it.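

In this assay the new methoxy gives a 4.7-fold lower number from compound 3 to compound 4 (0.67 log units; beyond the scatter), so the number falls by more than the usual scatter on this core. Set beside the earlier step, the same kind of change did not carry over from one core to the other: the same change on two cores in this assay, a 1.0-fold higher number (0.01 log units; within the scatter) from compound 1 to compound 2 and a 4.7-fold lower number (0.67 log units; beyond the scatter) from compound 3 to compound 4, 4.8-fold (0.68 log units) apart, beyond the scatter of two such steps. This does not show why the two steps differ, since they differ in the core and also in the place of the new group, which in compound 4 sits ortho to a group of 9 heavy atoms and meta to a methoxy group, and two steps alone cannot separate these.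

The compounds shown leave open whether a methoxy at that same place on the core of compound 1 would also lower the number, which would help to separate core from position. They also leave open whether a different group at that place, such as a hydroxyl, an amine or a carboxylic acid, would give a step of similar size.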